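Swapping the oxazole for an ethylsulfonylamino group

A few compounds are considered here, and "the series" means these few. Any claim that something is new, unique, unknown or untested is made for them only; others in the source may bear on it.

Three compounds sharing one core were tested in a functional assay on CHO cells for agonist activity at Alpha-1B adrenergic receptor (Homo sapiens), read by FLIPR and calcium flux; on this read-out lower numbers stand for an effect already at smaller amounts and higher numbers for an effect only at larger amounts of compound. Compound 1, `c1cc(-c2ccn[nH]2)c2c(c1)C(c1ncc[nH]1)CC2`, gives 600 nM in this assay. Compound 2, `Cn1cc(-c2cccc3c2CCC3c2ncc[nH]2)cn1`, returns only the limit > 10000 nM and no number. Compound 3, `c1cc(-c2ncco2)c2c(c1)C(c1ncc[nH]1)CC2`, likewise returns only the limit > 10000 nM. So compound 3 stands at the weak end of what was seen, at the limit of > 10000 nM in this assay, at which 2 of the 3 values shown sit. The step of an at least 16-fold higher number from compound 1 to compound 3 (1.22 log units; beyond the scatter) and the step of an at least 16-fold higher number from compound 1 to compound 2 (1.22 log units; beyond the scatter) are both large, while a step that the two limits leave unreadable from compound 2 to compound 3.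

Compound 4, `CCS(=O)(=O)Nc1cccc2c1CCC2c1ncc[nH]1`, is not yet measured. It differs from compound 3 in one place: (ethylsulfonyl)amino in place of 1,3-oxazol-2-yl on an aromatic carbon. Among the compounds with values here, no measured step covers this exact change; the two measured steps only show that both groups tried in place of the 1H-pyrazol-5-yl gave large losses. Since compound 3 sits at the limit, a step in either direction from it cannot be read with confidence. The expectation is that compound 4 stays near the limit, so a number no higher from compound 3 to compound 4 (the limit leaves the size open) is estimated as small, and compound 4 is expected to give about 10000 nM in this assay, within 2000 nM to 40000 nM.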

Compound 4, half-maximal effective concentration: > 10000 nM
Compound 4: only a limit was reported (the forecaster's own chance of this, stated with the estimate: 60%); the middle value lies on the limit itself.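

Within the data shown here, compound 4 places an open-chain group, (ethylsulfonyl)amino, on the aromatic carbon that carried only five-membered aromatic rings in the earlier compounds, and this group has a hydrogen-bond donor that the 1,3-oxazol-2-yl lacks. Even so, in this assay compound 4 returns > 10000 nM, which is a limit and not a number. Against the 1H-pyrazol-5-yl, the change gives an at least 16-fold higher number from compound 1 to compound 4 (1.22 log units; beyond the scatter), while the steps among compound 2, compound 3 and compound 4 cannot be read, so compound 1 remains the only compound here with a measured number, and the others all end at the same point: the limit of > 10000 nM in this assay, at which 3 of the 4 values shown sit.

Going by these compounds, it remains open whether activity at this position needs the 1H-pyrazol-5-yl ring itself. A 1,2,4-triazole ring or a simple primary amine on this carbon would help to show whether another group can restore it.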